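The source may report more compounds than this note shows. Statements on the series, on what has been measured and on what is new or still open speak of the compounds shown alone.

In a functional assay, with a stated time of 20 min, tested at 2 uM (on this read-out higher numbers stand for a stronger effect at the one concentration tested and lower numbers for a weaker effect), compound 2 `COc1cc(/C=C/C(=O)C2=C(/C=C/c3ccc(O)c(OC)c3)NC(=S)NC2c2ccccc2)ccc1O` gives 15.5%, the lower of the two numbers in hand. Compound 1 `COc1cc(/C=C/C(=O)C2=C(/C=C/c3ccc(O)c(OC)c3)NC(=O)NC2c2cccc([N+](=O)[O-])c2)ccc1O` gives 17%, and the two lie within the usual scatter of such measurements, so neither stands apart from the other. Compound 3 `COc1cc(/C=C/C(=O)C2=C(/C=C/c3ccc(O)c(OC)c3)NC(=S)NC2c2ccc(N(C)C)cc2)ccc1O` has not been measured; it differs from compound 2 by dimethylamino in place of hydrogen on an aromatic carbon. Among the compounds with values here, no step between measured compounds is in hand to point the direction of this change, so the expected step of a number 4.5 percentage points higher from compound 2 to compound 3 (within the scatter) is small and not beyond the scatter. Compound 3 is therefore estimated at about 20%, within a range from 8% to 36%.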

Compound 3, a percentage reported as activity, at one concentration (the size of the read-out at that concentration, not a potency): 30.2%
Compound 3: middle estimate off by 10.2 percentage points, on the low side; low and high end bracket the measured number.
By their numbers in this assay, from the lowest: compounds 2 and 1 (each within the scatter of the next); then compound 3.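

In this assay, within the data shown here, the change from phenyl to 4-(dimethylamino)phenyl gives a number 14.7 percentage points higher from compound 2 to compound 3 (beyond the scatter) and so provides the first step that can be read. It shows that the number responds to what stands on this aromatic carbon, para to a large group, and that dimethylamino here raises it rather than lowers it. No measurement on hand explains this rise. On these data alone, whether a primary amine, a methoxy group or a carboxylic acid at this place would raise the number too remains open.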